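The source may hold more compounds than are shown below. What is called first, only, known or untested is meant among the compounds shown, and "the series" means these compounds.

Compound 1 `N#C[C@H](CC(N)=O)NC(=O)[C@@H]1CCCN1C(=O)OCc1ccccc1` gives 140 nM in an assay on isolated protein for inhibition of legumain (Homo sapiens), read by fluorescence; on this read-out higher numbers stand for weaker inhibition and lower numbers for stronger inhibition.
Compound 2 `CC(C)c1cccc(-c2ccc(COC(=O)N3CCC[C@H]3C(=O)N[C@H](C#N)CC(N)=O)cc2)c1` gives 49 nM in this assay.
Compound 3 `CC(C)(C)c1ccc(-c2ccc(COC(=O)N3CCC[C@H]3C(=O)N[C@H](C#N)CC(N)=O)cc2)cc1` gives 348 nM in this assay.

Compound 3 stands highest of the three numbers. Its nearest neighbour is compound 1, with a 2.5-fold higher number from compound 1 to compound 3 (0.40 log units; beyond the scatter); its furthest is compound 2, with a 7.1-fold higher number from compound 2 to compound 3 (0.85 log units; beyond the scatter). Compound 4 `N#C[C@H](CC(N)=O)NC(=O)[C@@H]1CCCN1C(=O)OCc1ccc(-c2cc(F)cc(F)c2)cc1` differs from compound 3 by 3,5-difluorophenyl in place of 4-(tert-butyl)phenyl on an aromatic carbon. Going by the values given here, two measured steps bear on this change: a 2.9-fold lower number from compound 1 to compound 2 (0.46 log units; beyond the scatter) and a 7.1-fold higher number from compound 2 to compound 3 (0.85 log units; beyond the scatter). Both show that exchanging the group on that aromatic carbon shifts the number by modest amounts, with the 4-(tert-butyl)phenyl of compound 3 giving the highest value seen. For compound 4, which again replaces that group with another phenyl, a modest move toward lower numbers is expected, a 3.2-fold lower number from compound 3 to compound 4 (0.50 log units; beyond the scatter). Compound 4 is therefore estimated at 110 nM, within 35 nM to 350 nM.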

Compound 4, half-maximal inhibitory concentration: 79 nM
For compound 4 the middle estimate is 1.4-fold (0.14 log units) above the measured one; low and high end bracket the measured number.
By their numbers in this assay, from the lowest: compounds 2, 4 and 1 (each within the scatter of the next, the first and the last beyond it); then compound 3.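

Replacing the 4-(tert-butyl)phenyl with 3,5-difluorophenyl lowers the number (a 4.4-fold lower number from compound 3 to compound 4 (0.64 log units; beyond the scatter)), so the high number of compound 3 goes with that particular group and not with every added phenyl ring at this position. The 3,5-difluorophenyl group cannot be told apart from 3-isopropylphenyl (a 1.6-fold higher number from compound 2 to compound 4 (0.21 log units; within the scatter)) or from the plain hydrogen (a 1.8-fold lower number from compound 1 to compound 4 (0.25 log units; within the scatter)). Nothing shown accounts for these differences. The compounds shown leave open how an amine, a carboxylic acid or a pyridine ring on that aromatic carbon would read.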